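A few compounds are considered here, and "the series" means these few. Any claim that something is new, unique, unknown or untested is made for them only; others in the source may bear on it.

Working notes on the series. Compound 1 `COc1cc(CCc2ccc(Br)cc2)cc(OC)c1O` is the bromo member of this set; in a functional assay on HepG2 cells (Homo sapiens) for antiproliferative activity, read by MTT assay, with a stated time of 72 h (a lower number here means a stronger inhibitor, a higher number a weaker inhibitor), compound 1 gives 8490 nM. Two related members sit alongside it: compound 2 `COc1cc(CCc2ccccn2)cc(OC)c1O` gives 4840 nM, and compound 3 `COc1cc(CCc2ccc(Cl)cc2Cl)cc(OC)c1O` gives 6740 nM. Compound 1 carries the highest of the three numbers, yet both other values lie within the usual scatter of it, so no ranking among the three can be drawn from these figures.

Compound 4 `COc1cc(CCc2ccc([N+](=O)[O-])cc2)cc(OC)c1O` is the next member awaiting a number. It differs from compound 1 in one place: nitro in place of bromo on an aromatic carbon. Among the compounds with values here, no measured pair in the set shows the effect of this exchange, so nothing in the data anchors the step directly. Within the data shown here, three different substitution patterns on the pendant ring all land within scatter of one another, which is the only guide available. Compound 4 is therefore expected to show only a small step, a 1.2-fold lower number from compound 1 to compound 4 (0.08 log units; within the scatter), with no direction favoured beyond the scatter. For compound 4 the estimate is 7000 nM, expected to fall between 3000 nM and 17000 nM.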

Compound 4, half-maximal inhibitory concentration: 11000 nM
For compound 4 the middle estimate is 1.6-fold (0.20 log units) below the measured one, and the stated range covers the measured number.
By their numbers in this assay, from the lowest: compounds 2, 3, 1 and 4 (each within the scatter of the next, the first and the last beyond it).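

Within the data shown here, the exchange of bromo for nitro, on an aromatic carbon para to a large group, gives the one direct reading of a change at this position: in this assay it is a 1.3-fold higher number from compound 1 to compound 4 (0.11 log units; within the scatter). Replacing a single bromine with a group of three heavy atoms and two hydrogen-bond acceptors thus leaves the number within the scatter, so this pair shows no measurable effect of the exchange. No measured evidence bears on this result.

On these data alone, whether any group in this place can move the number beyond the scatter remains open, for example an amine or a carboxylic acid. Also open, as far as these compounds go, is whether a smaller substituent such as fluoro, or a hydrogen in place of bromo, would give a step of similar size.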